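The source may report more compounds than this note shows. Statements on the series, on what has been measured and on what is new or still open speak of the compounds shown alone.

Going by the values given here, compound 1 `Cc1ccc(C2=NN(c3nc(-c4ccc([N+](=O)[O-])cc4)cs3)C(c3ccc(F)cc3)C2)s1` is the only member of the series with a numerical reading in a functional assay on A549 cells (Homo sapiens) for antiproliferative activity, read by XTT assay, with a stated time of 24 h (a higher number here means a weaker inhibitor, a lower number a stronger inhibitor), where compound 1 gives 16.7 ug/mL. Among the compounds with values here, compound 2 `Fc1ccc(-c2csc(N3N=C(c4ccc(Cl)s4)CC3c3ccc(F)cc3)n2)cc1` differs from compound 1 in more than one place, so no single step joins the pair and only the two values themselves can be compared. In this assay compound 2 reaches only a limit, > 500 ug/mL, which is not a number. That limit is the one recorded in the series (the limit of > 500 ug/mL in this assay, at which 1 of the 2 values shown sits). Compound 3 `Cc1ccc(C2=NN(c3nc(-c4ccc(Cl)cc4)cs3)C(c3ccc(F)cc3)C2)s1` keeps the core of compound 1 and carries the change (chloro in place of nitro on an aromatic carbon), chloro in place of nitro on an aromatic carbon. Within the data shown here, no measured pair differs in this one place, so the size of the step cannot be read from the data. The step from compound 1 to compound 3 a 2.4-fold higher number from compound 1 to compound 3 (0.38 log units; beyond the scatter) is expected to be a modest weakening, possibly no larger than the scatter. Compound 3 is expected to give about 40 ug/mL in this assay, within 10 ug/mL to 250 ug/mL.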

Compound 3, half-maximal inhibitory concentration: > 500 ug/mL
Compound 3 ended at the assay's limit; the forecaster's own chance of this, stated with the estimate: 25%; middle value at least 12-fold (1.09 log units) from the limit.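

At this position, on a six-membered aromatic ring of carbon only and para to a large group, replacing nitro with chloro is not a minor change on the core of compound 1: in this assay the series now has its first readable step, an at least 29-fold higher number from compound 1 to compound 3 (1.47 log units; beyond the scatter). Compound 3 stands at a limit, so this step gives a bound and its full size stays unread. Compound 1 remains the only compound with a numerical reading, and the limit now accounts for most of the series: the limit of > 500 ug/mL in this assay, at which 2 of the 3 values shown sit.

From the compounds shown here alone, whether a measurable reading depends on nitro itself, or would also appear with a nitrile or an amine at this position, remains open. A single step at one position also says nothing about changes elsewhere on the core of compound 1.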